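Replacing piperidin-1-yl with diethylamino

The compounds below may be only part of what the source reports. "The series", "measured", "known", "first", "only" and "open" are said of these compounds alone.

Within the data shown here, in a functional assay on A549 cells (Homo sapiens) for cytotoxicity, read by MTT assay, with a stated time of 48 h (on this read-out lower numbers stand for stronger inhibition and higher numbers for weaker inhibition), compound 2 `COc1c(OCCCCN2CCCCC2)cc(O)c2c(=O)cc(-c3ccccc3)oc12` gives 1150 nM, the only true number in this small set. Compound 1 `CN1CCN(CCCOc2c(O)cc(O)c3c(=O)cc(-c4ccccc4)oc23)CC1` gives > 100000 nM, which is a limit of the assay and not a number. Compound 3 `O=c1cc(-c2ccccc2)oc2c(OCCCN3CCCC3)c(O)cc(O)c12` gives > 100000 nM, again a limit. So the picture is thin: the limit of > 100000 nM in this assay, at which 2 of the 3 values shown sit.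

Compound 4 `CCN(CC)CCCCOc1cc(O)c2c(=O)cc(-c3ccccc3)oc2c1OC` carries diethylamino in place of the piperidin-1-yl of compound 2, on a saturated chain carbon, four bonds along the chain from an oxygen on an aromatic ring: diethylamino in place of piperidin-1-yl on a saturated chain carbon, four bonds along the chain from an oxygen on an aromatic ring.

Among the measured compounds shown here, the only measured swap of one amine group for another is a step that the two limits leave unreadable from compound 1 to compound 3, so it offers no size to carry over. Its two compounds also differ from compound 2 elsewhere in the structure. The forecast therefore rests on compound 2 at 1150 nM, and no shift beyond the usual scatter is expected in this assay, though with wide uncertainty. The expected step is a 1.3-fold higher number from compound 2 to compound 4 (0.12 log units; within the scatter). The estimate for compound 4 is 1500 nM, with an expected range of 400 nM to 6000 nM.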

Compound 4, half-maximal inhibitory concentration: 1000 nM
Compound 4: middle estimate off by 1.5-fold (0.18 log units), on the high side; the range from low to high includes it.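

Among these compounds, this is the first swap of one amine for another in the set whose size can be read: in this assay it is a 1.2-fold lower number from compound 2 to compound 4 (0.06 log units; within the scatter). At this place, on a saturated chain carbon, four bonds along the chain from an oxygen on an aromatic ring, the six-membered ring of piperidin-1-yl can therefore give way to the ring-free diethylamino, with one heavy atom fewer, without a change beyond the scatter. Nothing measured here explains this result.

The step between compound 1 and compound 3 still cannot be read, as both of their values are limits of the assay, and both compounds also differ from compound 2 elsewhere in the structure. Also open, as far as these compounds go, is whether morpholin-4-yl or dimethylamino on the same chain, or diethylamino on a longer chain, would read the same.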